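The compounds below may be only part of what the source reports. "The series", "measured", "known", "first", "only" and "open" are said of these compounds alone.

Compound 1 `NC(=O)c1c(NC(=O)c2ccccc2Cl)sc2c1CCN(Cc1c(Cl)cccc1Cl)C2` gives 28800 nM in a functional assay on HeLa cells (Homo sapiens) for antiproliferative activity, with a stated time of 24 h; a higher number here means a weaker inhibitor, a lower number a stronger inhibitor. Compound 2 `NC(=O)c1c(NC(=O)c2ccccc2Cl)sc2c1CCN(C(=S)Nc1ccccc1I)C2`, which carries a thiourea-linked iodophenyl group on the ring nitrogen, gives 29000 nM in this assay, a change of a 1.0-fold higher number from compound 1 to compound 2 (0.00 log units; within the scatter). Compound 3 `COc1ccccc1NC(=S)N1CCc2c(sc(NC(=O)c3ccccc3Cl)c2C(N)=O)C1` reaches only the limit of the assay, > 50000 nM, which is the point at which (the limit of > 50000 nM in this assay, at which 1 of the 3 values shown sits); it is therefore a floor, not a number. The steps from compound 1 and compound 2 to it read an at least 1.7-fold higher number from compound 1 to compound 3 (0.23 log units; that floor lies within the scatter) and an at least 1.7-fold higher number from compound 2 to compound 3 (0.23 log units; that floor lies within the scatter), neither reaching beyond the scatter. Compound 4 `COc1ccccc1NC(=S)N1CCc2c(sc(NC(=O)c3ccccc3I)c2C(N)=O)C1` differs from compound 3 by iodo in place of chloro on an aromatic carbon. None of the measured steps touches this ring; the only halogen exchange shown, the methoxy for iodo change from compound 2 to compound 3, sits on the other aryl group and gave a floor only. With compound 3 already at the limit, the step to compound 4 is expected to be a step that the limit leaves unreadable from compound 3 to compound 4, and compound 4 is estimated at 60000 nM, between 25000 nM and 200000 nM, most probably again reported as a limit.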

Compound 4, half-maximal inhibitory concentration: > 50000 nM
Compound 4 ended at the assay's limit; the forecaster's own chance of this, stated with the estimate: 70%; the middle value does not contradict the limit.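

Compound 3 and compound 4 both stand at a limit rather than a number in this assay, so no step can be read between them: the limit of > 50000 nM in this assay, at which 2 of the 4 values shown sit.

As far as these compounds go, what iodo in place of chloro on this aromatic ring does to the read-out in this assay stays open.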